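Methyl on the core ring of compound 3

A few compounds are considered here, and "the series" means these few. Any claim that something is new, unique, unknown or untested is made for them only; others in the source may bear on it.

Compound 1 `Cc1cccc(Nc2nccc(-c3cc(C)oc3C)n2)c1` gives 28500 nM in a functional assay for inhibition, with Homo sapiens as the target; a higher number here means a weaker inhibitor, a lower number a stronger inhibitor. Compound 2 `Cc1cc(C)cc(Nc2nccc(-c3cc(C)oc3C)n2)c1` gives 4100 nM in this assay. The step of a 7.0-fold lower number from compound 1 to compound 2 (0.84 log units; beyond the scatter) follows from the change (methyl in place of hydrogen on an aromatic carbon). Compound 3 `c1ccc(Nc2nccc(-c3ccco3)n2)cc1` gives 32000 nM in this assay. The difference between the cores of compound 1 and compound 3 is not broken down here, and their two values lie within the scatter of each other.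

Compound 4 `Cc1cc(-c2ccco2)nc(Nc2ccccc2)n1` awaits measurement in this assay. It differs from compound 3 by methyl in place of hydrogen on an aromatic carbon. This is the same kind of change as from compound 1 to compound 2 but not the same: there the methyl entered on an aromatic carbon of a six-membered aromatic ring of carbon only, meta to a large group and meta to a methyl group, whereas here it enters on an aromatic carbon of a six-membered aromatic ring with 2 nitrogen, next to the ring nitrogen, meta to a furan-2-yl group, meta to a group of 7 heavy atoms and opposite the ring nitrogen. Within the data shown here, only one measured instance of this kind of change exists, and that on the other ring, so its effect on the core ring is unknown.

Compound 4 is expected to give 18000 nM in this assay, with a range from 5000 nM to 60000 nM. Among the measured compounds shown here, the expected step is a 1.8-fold lower number from compound 3 to compound 4 (0.25 log units; within the scatter), kept smaller than a 7.0-fold lower number from compound 1 to compound 2 (0.84 log units; beyond the scatter) as the only guide, with the change of place counted against carrying that step over in full.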

Compound 4, half-maximal inhibitory concentration: 17700 nM
For compound 4 the middle estimate is 1.0-fold (0.01 log units) above the measured one; low and high end bracket the measured number.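

In this assay the methyl on the core ring gives a 1.8-fold lower number from compound 3 to compound 4 (0.26 log units; within the scatter), a step that stays within the scatter on this core. The size of the step does not carry over unchanged between the two cores, and the methyl on the ring of carbon only gives the larger step: the same change on two cores in this assay, a 7.0-fold lower number (0.84 log units; beyond the scatter) from compound 1 to compound 2 and a 1.8-fold lower number (0.26 log units; within the scatter) from compound 3 to compound 4, 3.8-fold (0.58 log units) apart, beyond the scatter of two such steps. This does not show whether the core or the place of the methyl sets the gap, since the two steps differ in both, one with the methyl on a six-membered aromatic ring of carbon only and the other on a six-membered aromatic ring with 2 nitrogen, and two steps give no rule for any further core.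

The compounds shown leave open whether a methyl on the ring of carbon only, set on the core of compound 3, would repeat the larger step, which would separate the core from the place. They also leave open how a group other than methyl, such as an amine, a carboxylic acid or a longer chain, would read in the place that the methyl holds in compound 4.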